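Nitro for cyano on the benzyloxy aryl: cytotoxicity outlook

The source may hold more compounds than are shown below. What is called first, only, known or untested is meant among the compounds shown, and "the series" means these compounds.

Working notes on the shared core carried by compound 1, `CCOC(=O)c1cc(-c2cccc(OCc3cccc(Br)c3)c2)on1`, and compound 2, `CCOC(=O)c1cc(-c2cccc(OCc3cccc(C#N)c3)c2)on1`. In an ADME assay on Vero cells (Chlorocebus sabaeus) for cytotoxicity, with a stated time of 72 h (a lower number here means a stronger inhibitor, a higher number a weaker inhibitor), compound 1 gives only a limit, > 128000 nM. In this assay compound 2 likewise gives only a limit, > 128000 nM. Among the measured compounds shown here, the step between them, a step that the two limits leave unreadable from compound 1 to compound 2, cannot be read, since both ends sit at a limit; the only evidence on the measured steps is the limit of > 128000 nM in this assay, at which 2 of the 2 values shown sit. Compound 2 therefore stands at the limit of this assay, with no number to place it against compound 1.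

The next member, compound 3, `CCOC(=O)c1cc(-c2cccc(OCc3cccc([N+](=O)[O-])c3)c2)on1`, differs from compound 2 as follows: nitro in place of cyano on an aromatic carbon. For the measured compounds named here, no measured step in this assay bears on this change, and the one measured step is itself unreadable. With both measured values at the limit, no step beyond the scatter is expected in this assay in either direction. Compound 3 is expected to sit at or near the limit, estimated at 150000 nM with a range from 60000 nM to 400000 nM. The implied step, a step that the limit leaves unreadable from compound 2 to compound 3, is an estimate only.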

Compound 3, half-maximal inhibitory concentration: > 128000 nM
Compound 3 was reported as a limit; the forecaster's own chance of this, stated with the estimate: 85%; the middle value is on the limit's open side.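

No step can be read among compound 1, compound 2 and compound 3, since each gives only a limit in this assay: the limit of > 128000 nM in this assay, at which 3 of the 3 values shown sit.

The compounds shown leave open how bromo, cyano and nitro on the shared core would rank in this assay, and at what concentration any cytotoxicity would appear.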